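From 4-fluorophenyl to 4-bromo-2-fluorophenyl on a sulfonyl sulfur

A few compounds are considered here, and "the series" means these few. Any claim that something is new, unique, unknown or untested is made for them only; others in the source may bear on it.

Of the compounds shown here, three that share one core have been tested so far, and none of them gives a true number. In a functional assay on Huh-7 cells (Homo sapiens) for cytotoxicity, read by MTT assay, with a stated time of 72 h (on this read-out lower numbers stand for higher toxicity in this test and higher numbers for lower toxicity in this test), compound 1 `CS(=O)(=O)N1CCC2(CC1)OOC1(CCCCCC1)OO2` gives > 100 ug/mL as a limit, not a number. Compound 2 `O=S(=O)(CCCCl)N1CCC2(CC1)OOC1(CCCCCC1)OO2` gives > 100 ug/mL as a limit too. Compound 3 `O=S(=O)(c1ccc(F)cc1)N1CCC2(CC1)OOC1(CCCCCC1)OO2` gives > 100 ug/mL as a limit as well, so no number fixes where it stands. Together these readings make up the limit of > 100 ug/mL in this assay, at which 3 of the 3 values shown sit, and nothing more.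

Within the data shown here, the next compound, compound 4 `O=S(=O)(c1ccc(Br)cc1F)N1CCC2(CC1)OOC1(CCCCCC1)OO2` and still unmeasured, carries 4-bromo-2-fluorophenyl in place of 4-fluorophenyl on a sulfonyl sulfur as its only change. Two measured steps altered the group on that sulfur: a step that the two limits leave unreadable from compound 1 to compound 3 and also a step that the two limits leave unreadable from compound 2 to compound 3 and neither has a size that can be read. Going by compound 3 with its limit of > 100 ug/mL no change beyond the usual scatter is expected in this assay and no direction can be told. The expected step is a number no higher from compound 3 to compound 4 (the limit leaves the size open) and it remains an estimate. For compound 4 the estimated value is 100 ug/mL within an expected range from 50 ug/mL to 200 ug/mL and the reading may well turn out to be a limit again.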

Compound 4, half-maximal cytotoxic concentration: > 100 ug/mL
Compound 4: only a limit was reported (the forecaster's own chance of this, stated with the estimate: 80%); the middle value sits exactly at the limit.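

Compound 4, like compounds 1, 2 and 3, gives only a limit and not a number, so no step among these four compounds can be read in this assay: the limit of > 100 ug/mL in this assay, at which 4 of the 4 values shown sit.

The compounds shown leave open how far each true value lies from that limit, and whether any group on the sulfonyl sulfur changes the read-out at all.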